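A few compounds are considered here, and "the series" means these few. Any claim that something is new, unique, unknown or untested is made for them only; others in the source may bear on it.

In a physicochemical assay for solubility, read by HPLC, with a stated time of 20 h, at pH 1 (a lower number here means a less soluble compound, a higher number a more soluble compound), compound 1 `O=C(Nc1nc(Cc2ccccc2)no1)c1ccc(O[C@H]2CC[C@@H](C(=O)O)CC2)cc1` gives < 2000 nM, a limit of the assay and not a number. Compound 2 `CC(C)(O)CNC(=O)C[C@H]1CC[C@H](c2ccc(C(=O)Nc3nnc(Cc4ccccc4)s3)cc2)CC1` gives < 2000 nM, also a limit and not a number. Going by the values given here, the series so far therefore shows only (the limit of < 2000 nM in this assay, at which 2 of the 2 values shown sit). Compound 3 `COCCNC(=O)C[C@H]1CC[C@H](c2ccc(C(=O)Nc3nnc(Cc4ccccc4)s3)cc2)CC1` carries methoxymethyl in place of 1-hydroxy-1-methylethyl on a saturated chain carbon bound to an amide-type nitrogen. Among the compounds with values here, with no measured step to draw on, the expected change is no larger than the scatter, and no direction is assigned: a step that the limit leaves unreadable from compound 2 to compound 3. For compound 3 the estimate in this assay is 1500 nM, with an expected range of 500 nM to 3000 nM.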

Compound 3, solubility: < 2000 nM
Compound 3 ended at the assay's limit (the forecaster's own chance of this, stated with the estimate: 80%); the middle value lies beyond the limit too.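

No step can be read from compound 2 to compound 3 in this assay, since both end at a limit of the assay: the limit of < 2000 nM in this assay, at which 3 of the 3 values shown sit.

The compounds shown leave open where the actual solubility of compound 1, compound 2 and compound 3 lies, and whether methoxymethyl in place of 1-hydroxy-1-methylethyl alters it.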